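The compounds below may be only part of what the source reports. "The series", "measured", "known", "first", "only" and "open" are said of these compounds alone.

The compounds measured in an ADME assay on the whole organism with Oryza sativa as the target, tested at 1 uM (a lower number here means a stronger effect, a higher number a weaker effect of the compound at the concentration tested), are:

compound 1, `C[C@H](NC(=O)Nc1ccccc1F)c1ccccc1`, giving 92%
compound 2, `C[C@H](NC(=O)Nc1cccc(F)c1F)c1ccccc1`, giving 100%
compound 3, `C[C@@H](NC(=O)Nc1cccc(C(F)(F)F)c1F)c1ccccc1`, giving 99%

On these numbers compound 3 stands second highest of the three; its nearest neighbour is compound 2, and the number for compound 3 is a little higher than that of compound 2, while its furthest neighbour is compound 1, whose number is somewhat lower than that of compound 3. Both of these gaps lie within the scatter of the assay. Among the compounds with values here, the single step between measured compounds that differ in one place is a number 8 percentage points higher from compound 1 to compound 2 (within the scatter), and it too stays within the scatter.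

Compound 4, `C[C@H](NC(=O)Nc1cccc(C(F)(F)F)c1F)c1ccccc1`, has not yet been measured in this assay. Set against compound 3, the change is the two compounds have the same atoms and bonds and differ only in configuration as drawn: 1 of 1 stereo elements differ; a stereocentre at a saturated chain carbon is drawn R in compound 3 and S in compound 4. Within the data shown here, no measured step touches such a change in configuration; the one step known concerns a substituent on an aromatic ring and does not bear on it. With nothing pointing either way, a step of a number 3 percentage points lower from compound 3 to compound 4 (within the scatter) is expected, that is none beyond the scatter. Compound 4 is therefore estimated at 96%, in the range 80% to 100%.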

Compound 4, a percentage reported as activity, at one concentration (the size of the read-out at that concentration, not a potency): 98%
For compound 4 the middle estimate is 2 percentage points below the measured one; the range from low to high includes it.
By their numbers in this assay, from the lowest: compounds 1, 4, 3 and 2 (each within the scatter of the next).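

In this assay, within the data shown here, the first change at the stereocentre on the saturated chain carbon gives a number 1 percentage points lower from compound 3 to compound 4 (within the scatter), so the configuration drawn there, R or S, makes no readable difference, and this comparison isolates that one element: the fact that compounds 3 and 4 differ only in the configuration as drawn. Trifluoromethyl in place of fluoro gives a number 2 percentage points lower from compound 2 to compound 4 (within the scatter), and trifluoromethyl in place of hydrogen gives a number 6 percentage points higher from compound 1 to compound 4 (within the scatter), so neither replacement on the aromatic carbon moves the number beyond the scatter. Neither the configuration nor these two replacements had been tested by the earlier step, which concerned fluoro alone.

What the compounds leave open is whether an amine, a carboxylic acid or a longer chain in place of trifluoromethyl would give a step beyond the scatter. Among these compounds, with every step so far within the scatter, they also do not show which part of the structure, if any, governs this read-out.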